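This account rests on a few compounds, and the source may have more. Where it says the series, first, only, none or still open, it means among the compounds named here.

Values measured in a functional assay on HepG2 cells (Homo sapiens) for cytotoxicity, read by MTT assay, with a stated time of 48 h; on this read-out higher numbers stand for weaker inhibition and lower numbers for stronger inhibition:

- compound 1 `[O-][n+]1nc(NC2CC2)[n+]([O-])c2ccccc21`: 13300 nM
- compound 2 `[O-][n+]1nc(NC2CCCCC2)[n+]([O-])c2ccccc21`: 9500 nM
- compound 3 `CCCCCCCCNc1n[n+]([O-])c2ccccc2[n+]1[O-]`: 17400 nM

All three compounds share the same core and differ only in the group carried on the nitrogen outside the ring. Compound 3, at 17400 nM, lies within the usual scatter of both compound 1 and compound 2, so this assay does not separate it from either.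

The next compound is compound 4 `C=CCNc1n[n+]([O-])c2ccccc2[n+]1[O-]`, which has vinyl in place of heptyl on a saturated chain carbon bound to a nitrogen on an aromatic ring.

Among the measured compounds shown here, only one measured step bears on this change. It is a 1.4-fold lower number from compound 1 to compound 2 (0.15 log units; within the scatter), a swap of cyclopropyl for cyclohexyl that stays within the scatter. For the measured compounds named here, it is an indirect guide, since no measured pair shows what happens when heptyl is replaced by vinyl. Even so, the three values so far sit close together despite their different groups, so no step beyond the scatter is expected.

The estimated change is a 1.2-fold lower number from compound 3 to compound 4 (0.09 log units; within the scatter), which would not be a real difference. For compound 4 the expected value is 14000 nM, with an estimated range from 7000 nM to 28000 nM.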

Compound 4, half-maximal inhibitory concentration: > 56000 nM
Compound 4 ended at the assay's limit (the forecaster's own chance of this, stated with the estimate: 5%); middle value at least 4.0-fold (0.60 log units) away from the limit.
By their numbers in this assay, from the lowest: compounds 2, 1 and 3 (each within the scatter of the next). At a limit, above all of these: compound 4.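

In this assay compound 4 stands at a limit of the assay, not at an exact number: the limit of > 56000 nM in this assay, at which 1 of the 4 values shown sits. The earlier compounds shown here suggested that the group on the nitrogen outside the ring hardly mattered, but this change gives an at least 3.2-fold higher number from compound 3 to compound 4 (0.50 log units; beyond the scatter), as well as an at least 5.8-fold higher number from compound 2 to compound 4 (0.77 log units; beyond the scatter) and an at least 4.2-fold higher number from compound 1 to compound 4 (0.62 log units; beyond the scatter), so all three steps towards weaker inhibition lie beyond the scatter. This position can therefore affect the result, since replacing the cyclopropyl, cyclohexyl or long chain group with allyl is enough to separate compound 4 from the three compounds that could not be told apart.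

Compound 4 differs from compound 3 both in chain length and in having a double bond outside aromatic rings, so these compounds cannot show which difference matters, and a saturated propyl chain would help to separate the two. On these data alone, it also remains open how other groups at this position would behave, such as a benzyl group or a chain ending in an amine.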